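The source may hold more compounds than are shown below. What is called first, only, known or untested is meant among the compounds shown, and "the series" means these compounds.

Series on a shared core, compound 1 `O=C(O)CCc1ccc(OCc2ccccc2SC(F)(F)F)cc1`, measured in a functional assay on cells for agonist activity at Free fatty acid receptor 1 (Homo sapiens), read by FLIPR and calcium flux; a lower number here means a smaller maximal response, a higher number a larger maximal response. Compound 1 gives 74%. Compound 2 `Cc1cc(OCc2ccccc2SC(F)(F)F)ccc1CCC(=O)O` gives 108% in this assay, and compound 3 `Cc1cc(CCC(=O)O)ccc1OCc1ccccc1SC(F)(F)F` gives 81%. Compound 3 thus stands second highest of the three: its gap to compound 1 lies within the scatter, while compound 2 lies beyond the scatter on the high side. Compound 4 `Cc1cc(CCC(=O)O)cc(C)c1OCc1ccccc1SC(F)(F)F` differs from compound 3 by methyl in place of hydrogen on an aromatic carbon. Two measured steps involve the same kind of change: a number 34 percentage points higher from compound 1 to compound 2 (beyond the scatter), and a number 7 percentage points higher from compound 1 to compound 3 (within the scatter). One was large, the other within the scatter, so a moderate rise is the expectation for compound 4, about a number 11 percentage points higher from compound 3 to compound 4 (beyond the scatter). Compound 4 is therefore estimated at 92%, with a range of 72% to 115%.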

Compound 4, largest response reached (reported as percent of maximum), in percent of the reference or control that the assay uses: 115%
Beside the measured number, compound 4's estimate is 23 percentage points below it; the measured number falls inside the stated range.
By their numbers in this assay, from the lowest: compounds 1 and 3 (each within the scatter of the next); then compounds 2 and 4 (each within the scatter of the next).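

In this assay, methyl in place of hydrogen, ortho to a large group and meta to a 2-carboxyethyl group, gives a large step on a core that already carries a methyl group: a number 34 percentage points higher from compound 3 to compound 4 (beyond the scatter). The first methyl on the core of compound 1 gave a step within the scatter, a number 7 percentage points higher from compound 1 to compound 3 (within the scatter), so the size of this change depends on the core it is made on. The step also matches the other large one for this change: the same change on two cores in this assay, a number 34 percentage points higher (beyond the scatter) from compound 1 to compound 2 and a number 34 percentage points higher (beyond the scatter) from compound 3 to compound 4, 0 percentage points apart, within the scatter of two such steps

Going by these compounds, whether a larger group such as ethyl or methoxy would give the same rise at this position remains open. So does whether a chlorine atom would serve in place of either methyl of compound 4.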